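A few compounds are considered here, and "the series" means these few. Any claim that something is new, unique, unknown or untested is made for them only; others in the source may bear on it.

Measured so far in a functional assay on HUVEC cells (Homo sapiens), read by scintillation counting and thymidine incorporation, with a stated time of 24 h; on this read-out lower numbers stand for stronger inhibition and higher numbers for weaker inhibition

compound 1 `CCC(C)n1ncn(-c2ccc(N3CCN(c4ccc(OC[C@@H]5CO[C@@](CC)(c6ccc(Cl)cc6Cl)O5)cc4)CC3)cc2)c1=O` gives 353 nM
compound 2 `CCC(C)n1ncn(-c2ccc(N3CCN(c4ccc(OC[C@@H]5CO[C@@](Cc6ccccc6)(c6ccc(Cl)cc6Cl)O5)cc4)CC3)cc2)c1=O` gives 513 nM

Compound 2 at 513 nM has the higher of the two numbers, but it stands within the scatter of compound 1. Compound 3 `CCC(C)n1ncn(-c2ccc(N3CCN(c4ccc(OC[C@@H]5CO[C@@](CN(C)C)(c6ccc(Cl)cc6Cl)O5)cc4)CC3)cc2)c1=O` carries dimethylamino in place of phenyl on a saturated chain carbon bound to a saturated ring carbon, and the difference counts as dimethylamino in place of phenyl on a saturated chain carbon bound to a saturated ring carbon in full. For the measured compounds named here, no measured compound carries dimethylamino at this place, so the evidence is thin. Given a 1.5-fold higher number from compound 1 to compound 2 (0.16 log units; within the scatter) with phenyl in place of methyl, the one measured step at this place, no step beyond the scatter in either direction is expected in this assay for this change. The estimated move is a 1.3-fold lower number from compound 2 to compound 3 (0.11 log units; within the scatter) as a working figure. For compound 3 the expected value is 400 nM with an estimated range from 150 nM to 1100 nM on present evidence.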

Compound 3, half-maximal inhibitory concentration: 1400 nM
Beside the measured number, compound 3's estimate is 3.5-fold (0.54 log units) below it, and the stated range ends below it.
By their numbers in this assay, from the lowest: compounds 1 and 2 (each within the scatter of the next); then compound 3.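

In this assay, this place on a saturated chain carbon bound to a saturated ring carbon now shows that it responds to the group it carries: dimethylamino in place of phenyl gives a 2.7-fold higher number from compound 2 to compound 3 (0.44 log units; beyond the scatter), and dimethylamino in place of methyl gives a 4.0-fold higher number from compound 1 to compound 3 (0.60 log units; beyond the scatter). The earlier pair showed no such separation, and compound 3, the only one of the three with a nitrogen and a hydrogen-bond acceptor in this group, is the one that stands apart. Nothing at hand explains the difference.

On these data alone, it remains open whether the shift follows the nitrogen or dimethylamino in particular. A methoxy group, a primary amine and a morpholine at this place would help separate these readings, and a longer chain carrying the dimethylamino group would test how far the result extends.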